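This account rests on a few compounds, and the source may have more. Where it says the series, first, only, none or still open, it means among the compounds named here.

Compound 1 `CCc1noc(C)c1[C@@H]1C[C@@](C)(c2ccc(F)cc2F)N=C(N)S1` gives 41% in an ADME assay on microsomes from liver (Mus musculus) for metabolic stability, with a stated time of 10 min, tested at 0.5 uM; on this read-out lower numbers stand for a less stable compound and higher numbers for a more stable compound. Compound 2 `CCc1noc(CC)c1[C@@H]1C[C@@](C)(c2ccc(F)cc2F)N=C(N)S1` gives 59%. Compound 3 `Cc1onc(-c2ccc(F)cc2)c1[C@@H]1C[C@@](C)(c2ccc(F)cc2F)N=C(N)S1` gives 23%.

Among these three, compound 1 stands second highest: compound 2 lies above it, a number 18 percentage points higher from compound 1 to compound 2 (beyond the scatter), and compound 3 lies below it, a number 18 percentage points lower from compound 1 to compound 3 (beyond the scatter). Compound 4 `Cn1nccc1[C@@H]1C[C@@](C)(c2ccc(F)cc2F)N=C(N)S1` differs from compound 1 by 1-methyl-1H-pyrazol-5-yl in place of 3-ethyl-5-methyl-1,2-oxazol-4-yl on a saturated ring carbon. Neither measured step exchanges the whole five-membered ring, so they bear only loosely on this change. The step to compound 2 shows that adding a methyl raised the number; the step to compound 3 shows that a larger 4-fluorophenyl lowered it. Removing two alkyl groups and changing the ring points in no firm direction, so a step of at most modest size, possibly within the scatter, is expected, a number 3 percentage points lower from compound 1 to compound 4 (within the scatter). Compound 4 is therefore estimated at 38%, between 18% and 62%.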

Compound 4, percent of the compound remaining: 72%
Compound 4: middle estimate off by 34 percentage points, on the low side; measured number above the stated range.
By their numbers in this assay, from the lowest: compound 3; then compound 1; then compound 2; then compound 4.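

In this assay, 1-methyl-1H-pyrazol-5-yl in place of 3-ethyl-5-methyl-1,2-oxazol-4-yl on the saturated ring carbon gives a number 31 percentage points higher from compound 1 to compound 4 (beyond the scatter), a large step. This shows that the read-out at this position responds to exchanging the whole five-membered aromatic ring, not only to changing the groups it carries. Nothing measured here explains the step. The compounds shown leave open whether the new ring or the loss of the ethyl and methyl groups carries this step, and how a 1-ethyl-1H-pyrazol-5-yl group or a pyrazole bearing an amine would read.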